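Swapping the Amine Tail: What to Expect for Compound 4

A few compounds are considered here, and "the series" means these few. Any claim that something is new, unique, unknown or untested is made for them only; others in the source may bear on it.

Measured so far in a functional assay on SNU-16 cells (Homo sapiens) for antiproliferative activity, read by CCK-8 assay, with a stated time of 72 h; a lower number here means a stronger inhibitor, a higher number a weaker inhibitor:
compound 1 `COc1ccc(F)c(-c2ccc3c(NC(=O)c4ccc(N(C)CCN(C)C)cc4)n[nH]c3c2)c1F` gives 366 nM;
compound 2 `COc1ccc(F)c(-c2ccc3c(NC(=O)c4ccc(N5CCCN(C)CC5)cc4)n[nH]c3c2)c1F` gives 102 nM;
compound 3 `COc1ccc(F)c(-c2ccc3c(NC(=O)c4ccc(N5CCN(C)CC5)cc4)n[nH]c3c2)c1F` gives 35.6 nM.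

Compound 3 has the lowest number of the three: the steps of a 2.9-fold lower number from compound 2 to compound 3 (0.46 log units; beyond the scatter) and a 10-fold lower number from compound 1 to compound 3 (1.01 log units; beyond the scatter) both set it apart as the strongest inhibitor here. Compound 4 `COc1ccc(F)c(-c2ccc3c(NC(=O)c4ccc(N5C[C@@H](C)N[C@@H](C)C5)cc4)n[nH]c3c2)c1F` differs from it in one place: 3,5-dimethylpiperazin-1-yl in place of 4-methylpiperazin-1-yl on an aromatic carbon. All three measured steps vary this same tail, and each shifted this assay beyond the scatter, from the modest 3.6-fold lower number from compound 1 to compound 2 (0.55 log units; beyond the scatter) to the large 10-fold lower number from compound 1 to compound 3 (1.01 log units; beyond the scatter). None of them removes the methyl from the ring nitrogen or adds methyls on ring carbons, so the direction is uncertain. Compound 3 sits at the best point found, and a modest rise in number is expected for compound 4. Compound 4 is therefore estimated at 80 nM, within a range from 25 nM to 250 nM. The estimate amounts to an expected step of a 2.2-fold higher number from compound 3 to compound 4 (0.35 log units; beyond the scatter).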

Compound 4, half-maximal inhibitory concentration: 582 nM
For compound 4 the middle estimate is 7.3-fold (0.86 log units) below the measured one; the whole stated range lies below it.
By their numbers in this assay, from the lowest: compound 3; then compound 2; then compounds 1 and 4 (each within the scatter of the next).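

In this assay, keeping a piperazine ring on this aromatic carbon does not by itself keep the number low, as 3,5-dimethylpiperazin-1-yl brings a 16-fold higher number from compound 3 to compound 4 (1.21 log units; beyond the scatter). The larger 4-methyl-1,4-diazepan-1-yl tail does better, with a 5.7-fold higher number from compound 2 to compound 4 (0.76 log units; beyond the scatter), while the open-chain tail cannot be told apart, with a 1.6-fold higher number from compound 1 to compound 4 (0.20 log units; within the scatter). Nothing measured here accounts for the loss. From the compounds shown here alone, compound 4 drops the methyl on the ring nitrogen and gains methyls on ring carbons at once, and which of these matters stays open. A plain piperazine ring, with no methyl at all, would separate the two.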